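Swapping the Benzyl on the Ring Nitrogen for a Small Amide

This account rests on a few compounds, and the source may have more. Where it says the series, first, only, none or still open, it means among the compounds named here.

Three measured compounds share one core and differ only in the group carried on the ring nitrogen. In a functional assay (Cavia porcellus) for antagonist activity at thromboxane A2 receptor (Homo sapiens) (a higher number here means weaker binding, a lower number tighter binding), compound 3 `O=C(O)CC/C=C\C[C@@H]1CN(Cc2ccccc2)C[C@@H]1c1ccccc1O` gives 251 nM, the second highest of the three numbers. Compound 1 `O=C(O)CC/C=C\C[C@@H]1CN(Cc2cccnc2)C[C@@H]1c1ccccc1O` gives 1580 nM, and compound 2 `O=C(O)CCC/C=C\C[C@@H]1CN(S(=O)(=O)c2cccc3ccccc23)C[C@@H]1c1ccccc1O` gives 6.31 nM, a far lower number. Within the data shown here, the only single-change step measured, a 6.3-fold lower number from compound 1 to compound 3 (0.80 log units; beyond the scatter), moved the number modestly when one aromatic ring on that carbon was exchanged for another. Compound 4 `CC(C)C(=O)N1C[C@@H](C/C=C\CCC(=O)O)[C@@H](c2ccccc2O)C1` differs from compound 3 in one place: isopropylcarbonyl in place of benzyl on an amine nitrogen in a ring. Among the measured compounds shown here, no measured step covers trading an aromatic group for a small acyl group, so that step bears only loosely here; compound 2 carries a sulfonyl group on the nitrogen but also a longer acid chain, so its value cannot be read as a single step. The expected step is a 1.6-fold higher number from compound 3 to compound 4 (0.20 log units; within the scatter), and it is uncertain. Compound 4 is expected to give about 400 nM, with a range from 50 nM to 3000 nM.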

Compound 4, dissociation constant: 200 nM
The estimate for compound 4 lay 2.0-fold (0.30 log units) above the measured number; low and high end bracket the measured number.
By their numbers in this assay, from the lowest: compound 2; then compounds 4 and 3 (each within the scatter of the next); then compound 1.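

In this assay the exchange of benzyl for isopropylcarbonyl appears as a 1.3-fold lower number from compound 3 to compound 4 (0.10 log units; within the scatter) and stays within the usual scatter. Among these compounds, then, a benzyl ring on the ring nitrogen is not required to reach this level: a group with no ring and one hydrogen-bond acceptor gives a matching number. The same group in place of (pyridin-3-yl)methyl gives a 7.9-fold lower number from compound 1 to compound 4 (0.90 log units; beyond the scatter) and so leaves compound 1 apart from both compound 3 and compound 4, though nothing available explains why these groups compare as they do.

From the compounds shown here alone, whether the sulfonyl group of compound 2 would keep its low number on the 5-carboxypent-2-en-1-yl chain of compound 4 remains open. So does the outcome of an acetyl or a benzoyl group on the same nitrogen.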